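This account rests on a few compounds, and the source may have more. Where it says the series, first, only, none or still open, it means among the compounds named here.

In an ADME assay on the whole organism (Rattus norvegicus) for pharmacokinetics, at a dose of 1 mg/kg by the oral route (on this read-out lower numbers stand for lower exposure and higher numbers for higher exposure at the dose given), compound 1 `COc1ccc(F)cc1-c1ccnc2[nH]c(C3=CCC(C(=O)O)CC3)cc12` gives 3100 ng.h/mL. Compound 2 `COc1ccc(F)cc1-c1ccnc2[nH]c(C3=CCC(N[C@@H](C(=O)O)C(C)C)CC3)cc12` gives < 10 ng.h/mL, which is a limit of the assay and not a number. Compound 3 `COc1ccc(F)cc1-c1c(F)cnc2[nH]c(C3=CCN([C@H]4CC[C@@H](C(=O)O)CC4)CC3)cc12` gives 140 ng.h/mL, the lower of the two actual numbers in the series. Compound 4 `COc1ccc(F)cc1-c1c(F)cnc2[nH]c(C3=CCN([C@H]4CC[C@H](C(=O)O)CC4)CC3)cc12` differs from compound 3 as follows: the two compounds have the same atoms and bonds and differ only in configuration as drawn: 2 of 2 stereo elements differ (all stereocentres are inverted: mirror images); a stereocentre at a saturated ring carbon is drawn s in compound 3 and r in compound 4; a stereocentre at a saturated ring carbon is drawn s in compound 3 and r in compound 4. Among the measured compounds shown here, the only measured step, an at least 310-fold lower number from compound 1 to compound 2 (2.49 log units; beyond the scatter), replaces a group and leaves no measured guide to a change of configuration, so it bears on this pair only weakly. A moderate rise is expected, with the direction uncertain, and the expected change is a 1.8-fold higher number from compound 3 to compound 4 (0.25 log units; within the scatter). For compound 4 the estimate is 250 ng.h/mL, with an expected range of 50 ng.h/mL to 1200 ng.h/mL.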

Compound 4, area under the concentration-time curve: 450 ng.h/mL
The estimate for compound 4 lay 1.8-fold (0.26 log units) below the measured number; measured number inside the range.
By their numbers in this assay, from the lowest: compound 3; then compound 4; then compound 1. At a limit, below all of these: compound 2.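

In this assay the series now holds its first measured effect of configuration: a 3.2-fold higher number from compound 3 to compound 4 (0.51 log units; beyond the scatter). The earlier step replaced a group, whereas this one changes no atom or bond, and it still lies beyond the scatter. The difference can be assigned to configuration alone because of how the pair is related: the fact that compounds 3 and 4 differ only in the configuration as drawn

On these data alone, whether the same inversion gives a step of like direction and size with a primary amide or a tetrazole in place of the carboxylic acid remains open. Which of the two inverted stereocentres carries the step also remains open.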